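This account rests on a few compounds, and the source may have more. Where it says the series, first, only, none or still open, it means among the compounds named here.

In a functional assay on THP-1 cells (Homo sapiens) for inhibition, read by sulforhodamine B assay, with a stated time of 48 h (on this read-out higher numbers stand for weaker inhibition and lower numbers for stronger inhibition), compound 1 (`COc1ccc(C(c2ccc(OC(C)CN(C)C)cc2)c2cccc3ccccc23)c(OC)c1OC`) gives 15000 nM. Compound 2 (`COc1ccc(C(c2ccc(OCCO)cc2)c2cccc3ccccc23)c(OC)c1OC`) gives 16600 nM, within the scatter of compound 1. Compound 3 (`CCOC(=O)/C=C/CO/N=C(/c1ccc(OC)c(OC)c1OC)c1cccc2ccccc12`) gives > 20000 nM, which is a limit of the assay and not a number. Compound 4 (`C=CCOC(c1ccc(OC)c(OC)c1OC)c1cccc2ccccc12`) differs from compound 2 by allyloxy in place of 4-(2-hydroxyethoxy)phenyl on a saturated chain carbon bound to two aromatic carbons. Among the measured compounds shown here, only one measured step bears on this, and only loosely, since it alters the side group without removing the ring: a 1.1-fold higher number from compound 1 to compound 2 (0.04 log units; within the scatter). No change beyond the scatter is therefore expected, though any drift should be towards a higher number, and the limit of > 20000 nM in this assay, at which 1 of the 3 values shown sits, may be reached. The expected change is a 1.4-fold higher number from compound 2 to compound 4 (0.16 log units; within the scatter). Compound 4 is estimated at 24000 nM, with an expected range of 11000 nM to 45000 nM.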

Compound 4, half-maximal inhibitory concentration: > 20000 nM
Compound 4: no number, only a limit; the forecaster's own chance of this, stated with the estimate: 60%; the middle value is on the limit's open side.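

In this assay compound 4 gives > 20000 nM, which is a limit of the assay and not a number. The step is an at least 1.2-fold higher number from compound 2 to compound 4 (0.08 log units; that floor lies within the scatter); unlike the earlier change on an oxygen, this one removes a whole six-membered aromatic ring from the saturated chain carbon, and its true size cannot be read. This position can be followed no further here: the limit of > 20000 nM in this assay, at which 2 of the 4 values shown sit.

Going by these compounds, it remains open whether a carboxylic acid or a morpholine in place of allyloxy at this carbon would give a measurable number.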